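Replacing the aryloxy ring of a hydroxamate pair

A few compounds are considered here, and "the series" means these few. Any claim that something is new, unique, unknown or untested is made for them only; others in the source may bear on it.

Compound 1 `Cc1cc(F)cc(C)c1Oc1ccc(C(C)(C)O)cc1-c1cn(C)c(=O)c2[nH]c(C(=O)NCc3ccc(C(=O)NO)cc3)cc12`: in an assay on isolated protein for inhibition of protein deacetylase HDAC6 (Homo sapiens), read by fluorescence (on this read-out lower numbers stand for stronger inhibition and higher numbers for weaker inhibition), compound 1 gives 39.3 nM.
Compound 2 `Cc1cc(F)cc(C)c1Oc1ccc(C(C)(C)O)cc1-c1cn(C)c(=O)c2[nH]c(C(=O)NCCCCCCC(=O)NO)cc12`: in this assay compound 2 gives 17.2 nM.
Compound 3 `Cn1cc(-c2ccccc2Oc2ccccc2)c2cc(C(=O)NCCCCCC(=O)Nc3ccccc3N)[nH]c2c1=O`: in this assay compound 3 reaches only the limit > 500 nM.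

Among the two numbers recorded, compound 2 holds the lower one; the nearest neighbour is compound 1, and the change between them is a 2.3-fold lower number from compound 1 to compound 2 (0.36 log units; beyond the scatter). Compound 3 sits at the limit of > 500 nM in this assay, at which 1 of the 3 values shown sits, so it contributes a limit and not a number.

Compound 4 `Cn1cc(-c2cc(C(C)(C)O)ccc2Oc2ccc(F)cc2F)c2cc(C(=O)NCCCCCCC(=O)NO)[nH]c2c1=O` differs from compound 2 in one place: 2,4-difluorophenyl in place of 4-fluoro-2,6-dimethylphenyl on an oxygen on an aromatic ring. Going by the values given here, no measured step touches this ring. Among the compounds with values here, the single measured step, from compound 1 to compound 2, alters the hydroxamate-bearing chain and leaves the aryloxy group unchanged. Compound 3 carries an unsubstituted phenoxy ring, but it also carries a different end group, so its limit cannot be read as a statement about the ring alone. With nothing measured that bears on the change, the expected step is none beyond the scatter, given as a 1.3-fold higher number from compound 2 to compound 4 (0.11 log units; within the scatter). The estimate for compound 4 in this assay is therefore 22 nM, expected to lie between 8 nM and 65 nM.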

Compound 4, half-maximal inhibitory concentration: 8.7 nM
Compound 4: the middle estimate sits 2.5-fold (0.40 log units) above what was measured; the measured number falls inside the stated range.
By their numbers in this assay, from the lowest: compounds 4 and 2 (each within the scatter of the next); then compound 1. At a limit, above all of these: compound 3.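

Going by these compounds alone, with the hydroxamate chain and the shared core held constant, this is the only measured step that touches the aryl group on the oxygen: 2,4-difluorophenyl in place of 4-fluoro-2,6-dimethylphenyl gives a 2.0-fold lower number from compound 2 to compound 4 (0.30 log units; within the scatter) in this assay. At this position, therefore, the methyl groups of compound 2 can give way to the second fluorine of compound 4 without the number leaving the usual scatter, and the result offers no firm ranking of the two groups. Nothing measured in this set accounts for that outcome.

Going by these compounds, whether the same ring exchange would read the same way on the 4-(hydroxycarbamoyl)phenyl chain of compound 1 remains open, as that chain appears here only with 4-fluoro-2,6-dimethylphenyl. Also open is how far this position reaches beyond fluorinated and methylated phenyl rings, for instance with a pyridyl ring or a cyclohexyl group on the oxygen, since the compounds shown with the hydroxamate chain cover only these two aryl groups.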